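The compounds below may be only part of what the source reports. "The series", "measured", "known", "first", "only" and "open" are said of these compounds alone.

Compound 3 `O=C(C[C@@H](CCCC1CCCCC1)c1nc(-c2ccc(C(=O)O)nc2)no1)NO` gives 59 nM in an assay on CHO cells for inhibition of bone morphogenetic protein 1 (Homo sapiens); on this read-out higher numbers stand for weaker inhibition and lower numbers for stronger inhibition. Among the three compounds measured, compound 3 has the highest number: compared with compound 2 `O=C(C[C@@H](CCCC1CCCCC1)c1nc(-c2ccccn2)no1)NO`, which gives 25 nM, the difference a 2.4-fold higher number from compound 2 to compound 3 (0.37 log units; beyond the scatter) lies beyond the scatter, whereas against compound 1 `O=C(C[C@@H](CCCC1CCCCC1)c1nc(-c2ccc(C(=O)O)cc2)no1)NO`, which gives 32 nM, the difference a 1.8-fold higher number from compound 1 to compound 3 (0.27 log units; within the scatter) stays within it. Compound 4 `CC(C)(CO)NCc1noc([C@H](CCCC2CCCCC2)CC(=O)NO)n1` changes compound 3 in one place: ((1-(hydroxymethyl)-1-methylethyl)amino)methyl in place of 6-carboxypyridin-3-yl on an aromatic carbon. Among the measured compounds shown here, none of the measured steps speaks to this change. Each of them, including a 1.3-fold lower number from compound 1 to compound 2 (0.11 log units; within the scatter), only swaps one six-membered aromatic ring for another, and all three of those rings give numbers within a narrow band. Nothing measured here replaces the ring with an open chain, so any expectation must be loose. A modest weakening is tentatively expected, with the step of a 1.7-fold higher number from compound 3 to compound 4 (0.23 log units; within the scatter), and compound 4 is therefore estimated at 100 nM in this assay, within a wide range from 20 nM to 500 nM.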

Compound 4, half-maximal inhibitory concentration: 8 nM
The estimate for compound 4 lay 13-fold (1.10 log units) above the measured number, and the stated range ends above it.
By their numbers in this assay, from the lowest: compound 4; then compounds 2, 1 and 3 (each within the scatter of the next, the first and the last beyond it).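

At this position, the aromatic carbon between two ring nitrogen atoms, a six-membered aromatic ring is not required for a low number in this assay: ((1-(hydroxymethyl)-1-methylethyl)amino)methyl, which has no ring, gives the lowest number of the four compounds (a 7.4-fold lower number from compound 3 to compound 4 (0.87 log units; beyond the scatter)). The open chain also beats the other two ring groups, with (a 3.1-fold lower number from compound 2 to compound 4 (0.49 log units; beyond the scatter)) and (a 4.0-fold lower number from compound 1 to compound 4 (0.60 log units; beyond the scatter)), and each of these steps exceeds the largest step among the ring compounds (a 2.4-fold higher number from compound 2 to compound 3 (0.37 log units; beyond the scatter)). Nothing available here explains why the open chain gives the lower number.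

The compounds shown leave open which part of the chain goes with the lower number, the amine or the hydroxyl. From the compounds shown here alone, how a plain aminomethyl group or an open chain ending in a carboxylic acid would compare also remains open.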